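The source may report more compounds than this note shows. Statements on the series, on what has been measured and on what is new or still open speak of the compounds shown alone.

Three compounds were examined in a functional assay on the whole organism for inhibition, with Rattus norvegicus as the target, at a dose of 30 mg/kg; on this read-out lower numbers stand for less inhibition and higher numbers for more inhibition at the one dose given (going by the name of the read-out). Compound 1 `C/N=C(\S)n1nc(-c2cccc(Cl)c2)nc1N` gives 54% in this assay, compound 2 `C/N=C(\S)n1nc(-c2ccccc2Cl)nc1N` gives 18%, and compound 3 `C/N=C(\S)n1nc(-c2ccc(Cl)cc2Cl)nc1N` gives 91%. Compound 1 and compound 2 are built from the same atoms joined differently, and the difference between their two cores is not broken down here. From compound 2 to compound 3 the change is chloro in place of hydrogen on an aromatic carbon, and it brought a number 73 percentage points higher from compound 2 to compound 3 (beyond the scatter). Compound 4 `C/N=C(\S)n1nc(-c2ccc(Cl)c(Cl)c2)nc1N` is not yet measured. It differs from compound 1 by chloro in place of hydrogen on an aromatic carbon, the same kind of change, though here the entering chloro sits ortho to a chloro group rather than meta to one. Because a number 73 percentage points higher from compound 2 to compound 3 (beyond the scatter) was large, a step of a number 30 percentage points higher from compound 1 to compound 4 (beyond the scatter) is expected. The number in this assay has a ceiling, which limits the room above compound 1. Compound 4 is therefore estimated at 84%, between 62% and 97%.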

Compound 4, a percentage reported as inhibition, in the whole organism at one dose (the size of the read-out at that dose, not a potency): 85%
Compound 4: the middle estimate sits 1 percentage points below what was measured, and the stated range covers the measured number.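

In this assay, chloro in place of hydrogen on an aromatic carbon brought a number 31 percentage points higher from compound 1 to compound 4 (beyond the scatter). The direction of the step carried over from one core to the other, but its size did not: the same change on two cores in this assay, a number 73 percentage points higher (beyond the scatter) from compound 2 to compound 3 and a number 31 percentage points higher (beyond the scatter) from compound 1 to compound 4, 42 percentage points apart, beyond the scatter of two such steps Each step rests on a single pair and the entering chloro stands differently in the two, so the data do not separate an effect of the core from one of the chloro's place or of the ceiling on the read-out.

Chloro is the only substituent on the aromatic ring in the compounds shown, so how a fluoro, a methoxy or an amine there would read remains open. Going by these compounds, with a single dose, potency also remains open.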